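From a Methoxymethyl Group to a Fluorophenyl Ring

The source may report more compounds than this note shows. Statements on the series, on what has been measured and on what is new or still open speak of the compounds shown alone.

Compound 2 `COCc1ccc2nccc(SC3(C(=O)O)CCC3)c2c1` carries a methoxymethyl group on an aromatic carbon of the shared core. For the measured compounds named here, in an assay on HEK293 cells for inhibition of solute carrier family 22 member 12 (Homo sapiens), read by scintillation counting, with a stated time of 12 min (on this read-out higher numbers stand for weaker inhibition and lower numbers for stronger inhibition), compound 2 gives 198 nM, the lowest of the three numbers measured so far. Compound 3 `O=C(O)C1(Sc2ccnc3ccc(-c4cccc(C(F)(F)F)c4)cc23)CCC1`, which carries a 3-(trifluoromethyl)phenyl group on an aromatic carbon instead, gives 359 nM in this assay, and these two values lie within the scatter of each other. Compound 1 `N#CCOc1ccc2nccc(SC3(C(=O)O)CCC3)c2c1`, with a cyanomethoxy group, gives 680 nM in this assay; the change to compound 2 brought a 3.4-fold lower number from compound 1 to compound 2 (0.54 log units; beyond the scatter).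

Compound 4 `O=C(O)C1(Sc2ccnc3ccc(-c4ccccc4F)cc23)CCC1` has not yet been measured. It differs from compound 2 in one place: 2-fluorophenyl in place of methoxymethyl on an aromatic carbon. Going by the values given here, no measured step swaps a methoxymethyl group for an aryl ring, so the one measured step only shows that a change on this aromatic carbon can move the number beyond the scatter. The closest guide is compound 3, whose aryl ring on that aromatic carbon gives a number within the scatter of compound 2. Compound 4 is therefore expected to come in at about 300 nM, with a plausible range from 120 nM to 750 nM, close to the values of compound 2 and compound 3. The expected step is a 1.5-fold higher number from compound 2 to compound 4 (0.18 log units; within the scatter), a change within the scatter.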

Compound 4, half-maximal inhibitory concentration: 333 nM
Beside the measured number, compound 4's estimate is 1.1-fold (0.05 log units) below it; measured number inside the range.
By their numbers in this assay, from the lowest: compounds 2, 4, 3 and 1 (each within the scatter of the next, the first and the last beyond it).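

In this assay, for the compounds shown here, the change from methoxymethyl, an open chain of 3 heavy atoms, to 2-fluorophenyl, an aromatic ring group of 7 heavy atoms, gives a 1.7-fold higher number from compound 2 to compound 4 (0.23 log units; within the scatter), the first direct reading of a swap from a chain to a ring at this aromatic carbon. So the larger group with a ring leaves the number within the scatter of the smaller one, and this aromatic carbon accepts both groups with no clear separation between them in this assay. The same ring measured against cyanomethoxy gives a 2.0-fold lower number from compound 1 to compound 4 (0.31 log units; beyond the scatter), a modest step just beyond the scatter, and nothing available explains either step.

Going by these compounds, what a plain phenyl ring without the fluorine would give on this aromatic carbon stays open, so the share of the fluorine in the number of compound 4 cannot be told. On these data alone, it is also open how an amine or a longer chain would behave on this aromatic carbon, and whether any group there can move the number well below the values seen so far.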